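Bromo in place of chloro: the step to compound 3

A few compounds are considered here, and "the series" means these few. Any claim that something is new, unique, unknown or untested is made for them only; others in the source may bear on it.

Values measured so far in a functional assay on A-375 cells (Homo sapiens) for antiproliferative activity, read by MTT assay, with a stated time of 24 h (a higher number here means a weaker inhibitor, a lower number a stronger inhibitor), are these
- compound 1 `COc1cc(OC)c(-c2coc3cc(OCc4ccccc4)ccc3c2=O)cc1OC` gives 1640 nM
- compound 2 `COc1cc(OC)c(-c2coc3cc(OCc4ccccc4Cl)ccc3c2=O)cc1OC` gives 2020 nM

Only these two compounds have been measured, and compound 2 stands within the scatter of compound 1. The next compound to be measured is compound 3 `COc1cc(OC)c(-c2coc3cc(OCc4ccccc4Br)ccc3c2=O)cc1OC`, which keeps the shared core and changes one atom on the benzyl group. It has bromo in place of chloro on an aromatic carbon, so that 2-chlorobenzyl becomes 2-bromobenzyl bromo in place of chloro on an aromatic carbon in the otherwise unchanged structure. For the measured compounds named here, the one measured step that bears on this is a 1.2-fold higher number from compound 1 to compound 2 (0.09 log units; within the scatter), which came from chloro in place of hydrogen on an aromatic carbon. Going by the values given here, no measured compound carries bromo, so the data offer no direct reading of this exchange. Since the step to compound 2 was a 1.2-fold higher number from compound 1 to compound 2 (0.09 log units; within the scatter), no shift beyond the scatter is expected in this assay, in either direction. The expected step is a 1.0-fold higher number from compound 2 to compound 3 (0.02 log units; within the scatter) in this estimate. Compound 3 is therefore estimated at 2100 nM (expected range 1100 nM to 4000 nM).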

Compound 3, half-maximal inhibitory concentration: 2850 nM
Estimate against measurement, compound 3: 1.4-fold (0.13 log units) below, and the stated range covers the measured number.
By their numbers in this assay, from the lowest: compounds 1, 2 and 3 (each within the scatter of the next).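

In this assay, the exchange of chloro for bromo gives a 1.4-fold higher number from compound 2 to compound 3 (0.15 log units; within the scatter), and the comparison of bromo with hydrogen at the same aromatic carbon gives a 1.7-fold higher number from compound 1 to compound 3 (0.24 log units; within the scatter). With both steps inside the scatter, the three compounds do not separate at this place: benzyl, 2-chlorobenzyl and 2-bromobenzyl on the oxygen of the shared core cannot be told apart in this assay, and a second halogen now supports what chloro alone could only suggest. Nothing available accounts for these numbers or says what, if anything, the two halogens share in their action on these cells.

Still open, going by these compounds, is whether a group of a different kind on this aromatic carbon, such as an amine, a carboxylic acid or a methoxy group, would move the number beyond the scatter. On these data alone, it is equally open whether chloro or bromo on another carbon of the same ring, or a longer chain in place of the benzyl group, would leave the number as undisturbed as these exchanges did.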